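Chain-terminus variation on the shared core: compound 4

This account rests on a few compounds, and the source may have more. Where it says the series, first, only, none or still open, it means among the compounds named here.

Compound 1 `CSc1nc(NCCCc2ccccc2)c2ccccc2n1` — in an ADME assay on 184B5 cells (Homo sapiens) for cytotoxicity, read by MTT assay, with a stated time of 72 h (on this read-out higher numbers stand for weaker inhibition of growth and lower numbers for stronger inhibition of growth), compound 1 reaches only a limit of the assay, > 100000 nM.
Compound 2 `CSc1nc(NCCCCc2ccccc2)c2ccccc2n1` — in this assay compound 2 gives 53600 nM.
Compound 3 `CSc1nc(NCc2ccccc2)c2ccccc2n1` — in this assay compound 3 reaches only a limit of the assay, > 100000 nM.

Compound 3 thus has no number of its own; the limit of > 100000 nM in this assay, at which 2 of the 3 values shown sit, is where it stands. Compound 4 `CSc1nc(NCCCCCO)c2ccccc2n1` differs from compound 3 by 4-hydroxybutyl in place of phenyl on a saturated chain carbon bound to a nitrogen on an aromatic ring. Among the compounds with values here, the only step measured at the chain terminus, an at least 1.8-fold lower number from compound 1 to compound 2 (0.27 log units; that floor lies within the scatter), lengthens toward a benzyl and stays inside the scatter; no measured step exchanges the aromatic group for a hydroxyalkyl chain, so it bears only loosely on this change. In this assay no step beyond the scatter is expected, and the value is expected to remain at or near the limit. For compound 4 the estimate is 100000 nM, with a range of 40000 nM to 300000 nM. The expected step is a number no higher from compound 3 to compound 4 (the limit leaves the size open).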

Compound 4, concentration for total growth inhibition: > 100000 nM
Compound 4: only a limit was reported (the forecaster's own chance of this, stated with the estimate: 70%); the middle value sits exactly at the limit.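

Exchanging phenyl for 4-hydroxybutyl on the saturated chain carbon bound to the nitrogen leaves the series at the top of the measurable range: the limit of > 100000 nM in this assay, at which 3 of the 4 values shown sit. Within the data shown here, the one readable step is an at least 1.8-fold higher number from compound 2 to compound 4 (0.27 log units; that floor lies within the scatter), so a phenyl end and a hydroxymethyl end cannot yet be told apart in this assay. The steps to compound 4 from compound 1 and from compound 3 cannot be read, since both ends of each are limits.

On these data alone, whether an amine or a carboxylic acid at the chain end would give a value short of the limit remains open. As far as these compounds go, whether a longer chain ending in phenyl would move beyond compound 2 also remains open.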